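A few compounds are considered here, and "the series" means these few. Any claim that something is new, unique, unknown or untested is made for them only; others in the source may bear on it.

Compound 1 `COc1ccc(-n2nncc2CN2C(=O)C3(C(C#N)=C(N)Oc4c3c3nc5ccccc5nc3c3ccccc43)c3ccccc32)cc1` gives > 50000 nM in a functional assay on MCF7 cells (Homo sapiens) for antiproliferative activity, read by MTT assay, with a stated time of 48 h (a higher number here means a weaker inhibitor, a lower number a stronger inhibitor), a limit of the assay rather than a number. Compound 2 `CC(=O)Nc1ccc(-n2nncc2CN2C(=O)C3(C(C#N)=C(N)Oc4c3c3nc5ccccc5nc3c3ccccc43)c3ccccc32)cc1` gives > 50000 nM in this assay, also a limit. Compound 3 `CC(=O)Nc1ccc(-n2nncc2CN2C(=O)C3(C(C#N)=C(N)Oc4c(N)cc5nc6ccccc6nc5c43)c3ccccc32)cc1` gives > 50000 nM in this assay, again a limit.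

All three measured values sit at the same limit (the limit of > 50000 nM in this assay, at which 3 of the 3 values shown sit). Compound 2 and compound 1 share one core and differ only by methoxy in place of acetamido on an aromatic carbon; the step that the two limits leave unreadable from compound 2 to compound 1 cannot be read, as both values are limits. Compound 3 has a different core; the difference between the two cores is not broken down here.

Compound 4 `COc1ccc(-n2nncc2CN2C(=O)C3(C(C#N)=C(N)Oc4c(N)cc5nc6ccccc6nc5c43)c3ccccc32)cc1` is not yet measured. It differs from compound 3 by methoxy in place of acetamido on an aromatic carbon, the same change as from compound 2 to compound 1, at the same place. Compound 4 is expected to give about 60000 nM, between 20000 nM and 150000 nM, most likely reported only as a limit. This estimate means an expected step that the limit leaves unreadable from compound 3 to compound 4. The expectation rests on compound 3, whose value > 50000 nM is a limit of the assay.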

Compound 4, half-maximal inhibitory concentration: > 50000 nM
Compound 4: only a limit was reported (the forecaster's own chance of this, stated with the estimate: 85%); the middle value does not contradict the limit.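

Compound 3 and compound 4 both stop at a limit of the assay rather than a number, so no step between them can be read: the limit of > 50000 nM in this assay, at which 4 of the 4 values shown sit.

The compounds shown leave open how active any of them truly is, and whether methoxy in place of acetamido changes that activity at all.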